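A few compounds are considered here, and "the series" means these few. Any claim that something is new, unique, unknown or untested is made for them only; others in the source may bear on it.

Measured so far:
compound 1 `CC(=O)Nc1nc(-c2cccc(NS(=O)(=O)c3ccc(C#CC4CCCCC4)cc3)c2)cs1`: 1.2%
compound 2 `CC(=O)Nc1nc(-c2cccc(NS(=O)(=O)c3cccc(C#C[Si](C)(C)C)c3)c2)cs1`: 5.8%

Both numbers come from a functional assay on A-375 cells (Homo sapiens) for antiproliferative activity, read by trypan blue exclusion, with a stated time of 48 h, tested at 10 uM; on this read-out lower numbers stand for a stronger effect and higher numbers for a weaker effect at the one concentration tested. In it compound 1 gives 1.2% and compound 2 gives 5.8%; the gap between the two lies within the usual scatter of this kind of measurement, so they cannot be told apart, and each stands for a strong effect at the one concentration tested. Among the compounds with values here, no pair of measured compounds that differ in a single place is available, so nothing is yet known about how swapping one group shifts the read-out.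

Compound 3 `CCCCCCc1ccc(S(=O)(=O)Nc2cccc(-c3csc(NC(C)=O)n3)c2)cc1` has not yet been measured in this assay. It differs from compound 1 in one place: hexyl in place of 2-cyclohexylethynyl on an aromatic carbon. Within the data shown here, with no single-change step to lean on, the expectation for compound 3 rests only on how low compound 1 sits: the step of a number 6.8 percentage points higher from compound 1 to compound 3 (within the scatter) is expected to be a modest rise, possibly no larger than the scatter. Compound 3 is estimated at 8%, within a range from 1% to 35%.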

Compound 3, a percentage reported as activity, at one concentration (the size of the read-out at that concentration, not a potency): <= 1%
Compound 3 ended at the assay's limit; the forecaster's own chance of this, stated with the estimate: 0%; middle value at least 7 percentage points away from the limit.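

In this assay, the change at this aromatic carbon gives a number at least 0.2 percentage points lower from compound 1 to compound 3 (that floor lies within the scatter), so for this pair, a flexible hexyl with no ring keeps the strong effect seen with 2-cyclohexylethynyl, and neither the six-membered ring nor the triple bond is required for it at the one concentration tested. Compound 3 reads <= 1%, which is a limit of the assay and not a number. Any further separation between the two compounds cannot be seen at this end of the scale: the limit of <= 1% in this assay, at which 1 of the 3 values shown sits.

On these data alone, whether a short chain such as methyl, an amine or a carboxylic acid at this place would keep the read-out this low remains open. A single concentration also cannot tell how compound 1 and compound 3 compare in potency.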